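The compounds below may be only part of what the source reports. "The series", "measured", "known", "first", "only" and "open" are said of these compounds alone.

Working notes on the sulfonyl-aryl series. The shared core is kept throughout; only the aryl on the sulfonyl sulfur and the halogen on the core change. Within the data shown here, in an assay on isolated protein for displacement of a labelled ligand from metabotropic glutamate receptor 5 (Homo sapiens), with a stated time of 60 min, tested at 1 uM (on this read-out higher numbers stand for more inhibition at the one concentration tested (going by the name of the read-out) and lower numbers for less inhibition), compound 3 `CC1CCN(c2c(S(=O)(=O)c3cc(Cl)cc(Cl)c3)cnc3cc(Cl)ccc23)CC1` gives 93%, the highest of the three numbers so far. Compound 1 `CC1CCN(c2c(S(=O)(=O)c3ccc(Cl)cc3)cnc3cc(Cl)ccc23)CC1` stands within the scatter of it with 91%. Compound 2 `CC1CCN(c2c(S(=O)(=O)c3cc(F)cc(F)c3)cnc3cc(F)ccc23)CC1` differs from compound 3 in several positions at once. Compound 2 gives 77%, a number beyond the scatter below compound 3. Among the measured compounds shown here, the one measured step that changes only the sulfonyl aryl is a number 2 percentage points higher from compound 1 to compound 3 (within the scatter). Compound 4 `CC1CCN(c2c(S(=O)(=O)c3ccc(F)c(Cl)c3)cnc3cc(Cl)ccc23)CC1` is not yet measured; it differs from compound 3 by 3-chloro-4-fluorophenyl in place of 3,5-dichlorophenyl on a sulfonyl sulfur. For the measured compounds named here, since the single change on this aryl so far, a number 2 percentage points higher from compound 1 to compound 3 (within the scatter), stayed within the scatter, a step of no size beyond the scatter is the first expectation, tempered by compound 2 giving 77% as the only fluorine-bearing compound. For compound 4 the expected value in this assay is therefore 86%, within a range of 72% to 96%. That estimate means a step of a number 7 percentage points lower from compound 3 to compound 4 (within the scatter), expected to remain within the scatter.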

Compound 4, a percentage reported as inhibition, at one concentration (the size of the read-out at that concentration, not a potency): 94%
Compound 4: middle estimate off by 8 percentage points, on the low side, and the stated range covers the measured number.
By their numbers in this assay, from the lowest: compound 2; then compounds 1, 3 and 4 (each within the scatter of the next).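

On the sulfonyl sulfur, 3-chloro-4-fluorophenyl in place of 3,5-dichlorophenyl gives a number 1 percentage points higher from compound 3 to compound 4 (within the scatter) in this assay, and in place of 4-chlorophenyl it gives a number 3 percentage points higher from compound 1 to compound 4 (within the scatter). Among these compounds, this position therefore takes a fluorine-bearing aryl with a chlorine kept on the core and no step beyond the scatter, something the earlier compounds could not show, as their only aryl fluorine came with other changes. Nothing measured here explains why these three aryl groups read alike.

Compound 2 differs from the others in several places, so the aryl and core halogens cannot be separated as sources of its lower number. From the compounds shown here alone, whether an aryl carrying an amine or a carboxylic acid instead of halogens also stays within the scatter remains open.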